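A few compounds are considered here, and "the series" means these few. Any claim that something is new, unique, unknown or untested is made for them only; others in the source may bear on it.

Measured in an ADME assay on the whole organism (plasma, Rattus norvegicus) for protein binding, using cassette dosing, at a dose of 1 mg/kg (on this read-out higher numbers stand for a larger free fraction and lower numbers for a smaller free fraction), so far:
- compound 2, `C[C@@H](Cn1c(=O)[nH]/c(=N\c2ccc(Oc3cccc(F)n3)cc2)n(Cc2ccc(Cl)cc2)c1=O)C(=O)O`: 0.007
- compound 3, `Cc1ccc(Cn2c(=O)n(CC(C)(C)C(=O)O)c(=O)[nH]/c2=N\c2ccc(OC(C)C)c(Cl)c2)cc1`: 0.01
- compound 1, `CC(C)Oc1ccc(Nc2nc(=O)n(CCCO)c(=O)n2Cc2ccc(Cl)cc2)cc1Cl`: 0.003

Among these three, compound 2 sits second highest. Compound 3 and compound 2 lie within the usual scatter of each other, so no order between them can be read. Compound 1 lies beyond the scatter below compound 2.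

The unmeasured compound 4, `C[C@@H](Cn1c(=O)[nH]/c(=N\c2ccc(Oc3ccnc(F)c3)cc2)n(Cc2ccc(Cl)cc2)c1=O)C(=O)O`, differs from compound 2 in one place: 2-fluoropyridin-4-yl in place of 6-fluoropyridin-2-yl on an oxygen on an aromatic ring. Going by the values given here, no measured pair shows this change, so the expectation rests on the shared core and on compound 2 alone. As the same atoms are merely joined differently, no step beyond the scatter is expected in this assay; the expected change from compound 2 to compound 4 is no change at the digits printed from compound 2 to compound 4 (within the scatter). Compound 4 is therefore estimated at 0.007, with a range from 0.004 to 0.014.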

Compound 4, unbound fraction: 0.013
The estimate for compound 4 lay 1.9-fold (0.27 log units) below the measured number; the measured number falls inside the stated range.
By their numbers in this assay, from the lowest: compound 1; then compounds 2, 3 and 4 (each within the scatter of the next).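

In this assay, the exchange of 6-fluoropyridin-2-yl for 2-fluoropyridin-4-yl on an oxygen on an aromatic ring gives a 1.9-fold higher number from compound 2 to compound 4 (0.27 log units; within the scatter), the only one-place comparison shown here. Going by these compounds alone, at this position, joining the same atoms differently therefore gives no step that can be told from the usual scatter. No supporting measurement bears on this result.

The compounds shown leave open whether a plain phenyl, or a pyridine carrying an amine instead of fluorine, would give a step beyond the scatter at this position.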